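Replacing 2-chlorophenyl in compound 3

The source may hold more compounds than are shown below. What is called first, only, known or untested is meant among the compounds shown, and "the series" means these compounds.

Values measured in a functional assay on MDA-MB-231 cells (Homo sapiens) for antiproliferative activity, read by MTT assay, with a stated time of 48 h (a higher number here means a weaker inhibitor, a lower number a stronger inhibitor), follow.
Compound 1 `C/C(=C\CC/C(C)=C/CC[C@@H]1[C@@]2(C)CCC(=O)C(C)(C)[C@H]2CC[C@@]1(C)O)CC/C=C(\C)C(=O)OCc1cn(-c2cccc(Cl)c2)nn1` (103000 nM)
Compound 2 `C/C(=C\CC/C(C)=C/CC[C@@H]1[C@@]2(C)CCC(=O)C(C)(C)[C@H]2CC[C@@]1(C)O)CC/C=C(\C)C(=O)OCc1cn(-c2cccc(F)c2)nn1` (144000 nM)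
Compound 3 `C/C(=C\CC/C(C)=C/CC[C@@H]1[C@@]2(C)CCC(=O)C(C)(C)[C@H]2CC[C@@]1(C)O)CC/C=C(\C)C(=O)OCc1cn(-c2ccccc2Cl)nn1` (> 150000 nM) a limit of the assay

Compound 3 has no number, only a limit (the limit of > 150000 nM in this assay, at which 1 of the 3 values shown sits). Compound 4 `C/C(=C\CC/C(C)=C/CC[C@@H]1[C@@]2(C)CCC(=O)C(C)(C)[C@H]2CC[C@@]1(C)O)CC/C=C(\C)C(=O)OCc1cn(-c2cccc(C(F)(F)F)c2)nn1` carries 3-(trifluoromethyl)phenyl in place of 2-chlorophenyl on an aromatic nitrogen. Among the measured compounds shown here, three measured steps bear on this change. Compound 1 carries 3-chlorophenyl and compound 2 carries 3-fluorophenyl, and the step between them is small (a 1.4-fold higher number from compound 1 to compound 2 (0.15 log units; within the scatter)). The steps to 2-chlorophenyl are also small (an at least 1.4-fold higher number from compound 1 to compound 3 (0.16 log units; that floor lies within the scatter)) and (an at least 1.0-fold higher number from compound 2 to compound 3 (0.01 log units; that floor lies within the scatter)). On these steps, no change beyond the scatter is expected in this assay for the estimated step (an at least 1.2-fold lower number from compound 3 to compound 4 (0.09 log units; that floor lies within the scatter)). For compound 4 the expected value is 120000 nM within an estimated range from 70000 nM to 160000 nM in this account.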

Compound 4, half-maximal inhibitory concentration: > 150000 nM
Compound 4 was reported as a limit; the forecaster's own chance of this, stated with the estimate: 25%; middle value at least 1.2-fold (0.09 log units) away from the limit.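

Compound 4 is reported in this assay as a limit of the assay, not a number: the limit of > 150000 nM in this assay, at which 2 of the 4 values shown sit.

Compound 3 sits at the same limit, so the step between these two cannot be read, and 3-(trifluoromethyl)phenyl joins 2-chlorophenyl there. The other steps are only floors, an at least 1.0-fold higher number from compound 2 to compound 4 (0.01 log units; that floor lies within the scatter) and an at least 1.4-fold higher number from compound 1 to compound 4 (0.16 log units; that floor lies within the scatter), so trifluoromethyl gives no sign of a stronger inhibitor than fluoro or chloro.

As far as these compounds go, how far compound 3 and compound 4 lie past the limit stays open. Also open, from the compounds shown here alone, is whether an amine or a carboxylic acid on this phenyl group, in place of trifluoromethyl, would change the value beyond the scatter.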